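The compounds below may be only part of what the source reports. "The series", "measured", "known", "first", "only" and "open" are said of these compounds alone.

Measured compounds in a functional assay on HepG2 cells (Homo sapiens) for antiproliferative activity, read by MTT assay, with a stated time of 24 h; a higher number here means a weaker inhibitor, a lower number a stronger inhibitor:
- compound 1 `COc1ccc(C(=O)/C=C/c2ccc(F)cc2)c2c1C=CC(C)(C)O2`: > 10000 nM (a limit of this assay, not a number)
- compound 2 `COc1ccc(C(=O)/C=C/c2ccc3ccccc3c2)c2c1C=CC(C)(C)O2`: 210 nM
- compound 3 `COc1ccc(C(=O)/C=C/c2ccc(OC)c(OC)c2OC)c2c1C=CC(C)(C)O2`: > 10000 nM (a limit of this assay, not a number)

Compound 1 stands at the limit of this assay, with no number of its own. Compound 3 sits at the same limit. For the measured compounds named here, of the three, only compound 2 returns a number, and it lies well clear of that limit; the limit of > 10000 nM in this assay, at which 2 of the 3 values shown sit, is where the other two values sit, so no measured single-point step can be drawn between them.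

Compound 4 `COc1ccc(C(=O)/C=C/c2cccs2)c2c1C=CC(C)(C)O2` is not yet measured. It differs from compound 1 as follows: thiophen-2-yl in place of 4-fluorophenyl on a double-bonded chain carbon bound to a double-bonded chain carbon. Since compound 1 is known only as a limit, any step from it can only be read as a lower bound on whatever compound 4 returns. Going by the values given here, nothing among the measured compounds speaks for a move toward the potency of compound 2, and the most likely outcome is that compound 4 again sits at the limit, with at most a step of modest size expected as a step that the limit leaves unreadable from compound 1 to compound 4. Compound 4 is therefore estimated at 12000 nM, within a range of 3000 nM to 40000 nM.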

Compound 4, half-maximal inhibitory concentration: > 10000 nM
Compound 4 ended at the assay's limit; the forecaster's own chance of this, stated with the estimate: 65%; the middle value is on the limit's open side.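

For the compounds shown here, compound 1 and compound 4 both stand at a limit in this assay, not at a number, so no step between them can be read: the limit of > 10000 nM in this assay, at which 3 of the 4 values shown sit. The compounds shown leave open how thiophen-2-yl and 4-fluorophenyl compare on the shared core.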